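Tolerance limits and the step to compound 4

The source may report more compounds than this note shows. Statements on the series, on what has been measured and on what is new or still open speak of the compounds shown alone.

In an ADME assay on HepG2 cells (Homo sapiens) for cytotoxicity, read by MTT assay, with a stated time of 72 h (a higher number here means that more compound is tolerated, a lower number that less compound is tolerated), three compounds on the shared core have been read so far. Compound 1 `COc1ccc(C#Cc2cc(Cl)cn3c([N+](=O)[O-])c(CS(=O)(=O)c4ccccc4)nc23)cc1` gives > 3900 nM, which is a limit. Compound 2 `Nc1ccc(C#Cc2cc(Cl)cn3c([N+](=O)[O-])c(CS(=O)(=O)c4ccccc4)nc23)cc1` gives > 3900 nM, also a limit. Compound 3 `O=[N+]([O-])c1c(CS(=O)(=O)c2ccccc2)nc2c(C#Cc3cccnc3)cc(Cl)cn12` gives > 3900 nM, again a limit and not a number. The whole picture so far is the limit of > 3900 nM in this assay, at which 3 of the 3 values shown sit.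

Compound 4 `O=[N+]([O-])c1c(CS(=O)(=O)c2ccccc2)nc2c(C#Cc3ccc(CO)cc3)cc(Cl)cn12` carries 4-(hydroxymethyl)phenyl in place of pyridin-3-yl on a triple-bonded carbon.

Two measured changes fall at this same place: a step that the two limits leave unreadable from compound 1 to compound 3, and a step that the two limits leave unreadable from compound 2 to compound 3. A third change, amino in place of methoxy on an aromatic carbon, is a step that the two limits leave unreadable from compound 1 to compound 2. Among the measured compounds shown here, none of the three has a readable size, so the series offers no measured step to carry over. All three compounds, with 4-methoxyphenyl, 4-aminophenyl or pyridin-3-yl on that carbon, sit at the same limit. No step beyond the scatter is therefore expected in this assay, in either direction, and a further report as a limit is the likeliest outcome. The expected step is a step that the limit leaves unreadable from compound 3 to compound 4. For compound 4 the estimated value is 5000 nM, with an expected range from 2500 nM to 15000 nM.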

Compound 4, half-maximal cytotoxic concentration: > 15600 nM
Compound 4: only a limit was reported; the forecaster's own chance of this, stated with the estimate: 75%; middle value at least 3.1-fold (0.49 log units) from the limit.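

In this assay compound 4 gives > 15600 nM, which is a limit and not a number. Compound 3 gives > 3900 nM, also a limit. Among the compounds shown here, no step from compound 1, compound 2 or compound 3 to compound 4 can be read. Open, going by these compounds, is where the actual tolerated concentrations of these four compounds lie, and whether they differ at all in this assay.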